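The source may report more compounds than this note shows. Statements on the series, on what has been measured and on what is new or still open speak of the compounds shown alone.

Compound 1 `COc1cccc(N2CCN(C(=O)C(C)N3C(=O)CCC3=O)CC2)c1` gives 0% in a functional assay on the whole organism (strain Swiss) with Mus musculus as the target, in the maximal electroshock model, with a stated time of 1 h, at a dose of 300 mg/kg by the intraperitoneal route; on this read-out higher numbers stand for a stronger effect at the one dose given and lower numbers for a weaker effect.
Compound 2 `CCC(C(=O)N1CCN(c2ccc(C(F)(F)F)cc2)CC1)N1C(=O)CCC1=O` gives 0% in this assay.
Compound 3 `CCC(C(=O)N1CCOCC1)N1C(=O)CCC1=O` gives 0% in this assay.

On these numbers compound 1 stands level with compound 2 and with compound 3 at the digits reported: none of the three shows any effect, and the differences between them lie within the scatter of the method. For the measured compounds named here, no compound among the three can be called stronger or weaker than another.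

The account follows the step from compound 1 to compound 4 `CC(C(=O)N1CCN(c2ccccc2F)CC1)N1C(=O)CCC1=O`, which has not yet been measured in this assay. The change is 2-fluorophenyl in place of 3-methoxyphenyl on an amine nitrogen in a ring. Going by the values given here, no pair of measured compounds differs in only one place, so there is no measured step to lean on for the size of this change. The three measured values together give no sign that any variation of the aryl group on the ring nitrogen moves the read-out off zero.

Compound 4 is therefore expected to stay where compound 1 stands, with a step of a number 5 percentage points higher from compound 1 to compound 4 (within the scatter) that is estimated to be none beyond the scatter. The estimate for compound 4 in this assay is 5%, within a range from 0% to 25%.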

Compound 4, a percentage reported as activity, at one dose (the size of the read-out at that dose, not a potency): 50%
Compound 4: the middle estimate sits 45 percentage points below what was measured, and the stated range ends below it.
By their numbers in this assay, from the lowest: compounds 1, 2 and 3 (each within the scatter of the next); then compound 4.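

Putting 2-fluorophenyl in place of 3-methoxyphenyl on an amine nitrogen in a ring gives, in this assay, a number 50 percentage points higher from compound 1 to compound 4 (beyond the scatter), which shows that the read-out responds to the group at this position. For the compounds shown here, the earlier compounds could not show this, as none of them had any effect and no two of them differed in only one place, so this is the first step that can be read and it is a large one. Nothing available explains why this change has such an effect.

The step replaces one substituent with another and also changes the number in the group's name, so the compounds shown do not tell whether the gain goes with the fluorine, with its place on the phenyl ring, or with the loss of the methoxy group, a question that 3-fluorophenyl, 2-methoxyphenyl, 2-chlorophenyl or plain phenyl could address. Because the read-out comes from a single dose, they also leave open how potent compound 4 is and whether the gain would carry over to the core of compound 2, which bears an ethyl group where compound 4 bears a methyl group.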